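Sulfonamide aryl substituent: cyano replaced by methyl

The compounds below may be only part of what the source reports. "The series", "measured", "known", "first", "only" and "open" are said of these compounds alone.

Compound 1 `COc1n[nH]c2ncc(-c3cn(-c4c(F)ccc(NS(=O)(=O)c5ccccc5)c4F)nn3)cc12` carries an unsubstituted phenylsulfonyl group on the shared core; in an assay on Sf9 cells for inhibition of mitogen-activated protein kinase kinase kinase 20 (Homo sapiens), read by ADP-Glo, with a stated time of 30 min (on this read-out lower numbers stand for stronger inhibition and higher numbers for weaker inhibition), compound 1 gives 3.8 nM. Compound 2 `COc1n[nH]c2ncc(-c3cn(-c4c(F)ccc(NS(=O)(=O)c5cccc(C#N)c5)c4F)nn3)cc12` adds a nitrile to that ring, and in this assay compound 2 gives 3.3 nM. The step of a 1.2-fold lower number from compound 1 to compound 2 (0.06 log units; within the scatter) shows that the two numbers cannot be told apart; compound 2 and compound 1 stand within the scatter of each other, with no separation on the numbers shown.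

Compound 3 `COc1n[nH]c2ncc(-c3cn(-c4c(F)ccc(NS(=O)(=O)c5cccc(C)c5)c4F)nn3)cc12` differs from compound 2 by methyl in place of cyano on an aromatic carbon. Within the data shown here, the only step that bears on this position, a 1.2-fold lower number from compound 1 to compound 2 (0.06 log units; within the scatter), was within the scatter, so the position has so far tolerated hydrogen and cyano alike. The step from compound 2 to compound 3 is therefore expected to be a 1.2-fold higher number from compound 2 to compound 3 (0.06 log units; within the scatter), which is no change beyond the scatter. For compound 3 the expected value in this assay is 3.8 nM, with a range of 1.5 nM to 9.5 nM.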

Compound 3, half-maximal inhibitory concentration: 4.4 nM
Compound 3: the middle estimate sits 1.2-fold (0.06 log units) below what was measured; low and high end bracket the measured number.
By their numbers in this assay, from the lowest: compounds 2, 1 and 3 (each within the scatter of the next).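

In this assay, methyl in place of cyano gives a 1.3-fold higher number from compound 2 to compound 3 (0.12 log units; within the scatter) and methyl in place of hydrogen gives a 1.2-fold higher number from compound 1 to compound 3 (0.06 log units; within the scatter) on the same aromatic carbon. This position has now taken hydrogen, a nitrile and a methyl group with no separation among the three compounds, so a small carbon substituent without a triple bond and without a hydrogen-bond acceptor fits as well as the nitrile on these numbers. Nothing available explains why these three groups cannot be told apart.

Still open, as far as these compounds go, is whether an amine, a carboxylic acid or a longer chain at this position would move the number beyond the scatter. The same question stands for a methyl group or a nitrile elsewhere on this aromatic ring.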